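Amide substituent variation on the shared nucleoside core

The source may report more compounds than this note shows. Statements on the series, on what has been measured and on what is new or still open speak of the compounds shown alone.

Measured so far:
compound 1 `CCCCCCCCCNC(=O)[C@H]1OC(n2cnc3c(N)ncnc32)[C@H](O)[C@@H]1O` — 31 nM in an assay on cell membranes for binding affinity to 2-oxoglutarate receptor 1 (Rattus norvegicus), read by radioligand binding; on this read-out lower numbers stand for stronger inhibition and higher numbers for weaker inhibition
compound 2 `CCCCCCCCCCCCNC(=O)[C@H]1OC(n2cnc3c(N)ncnc32)[C@H](O)[C@@H]1O` — 163 nM in this assay

The series keeps the shared core of compound 1 and varies only the group on the amide-type nitrogen. Among the measured compounds shown here, compound 1 carries a nonyl chain and gives the lowest number of the two measured, with compound 2 as its only neighbour. Extending the chain, a 5.3-fold higher number from compound 1 to compound 2 (0.72 log units; beyond the scatter), weakens binding by a modest but clear amount.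

Compound 3 `Nc1ncnc2c1ncn2C1O[C@H](C(=O)NC2CC3CCC2C3)[C@@H](O)[C@H]1O` is not yet measured. It differs from compound 1 in a single place: a group of 7 heavy atoms (7 carbon; 2 five-membered non-aromatic rings of carbon only) in place of a group of 9 heavy atoms (9 carbon; no ring), on an amide-type nitrogen. For the measured compounds named here, no measured step covers a ring-containing group at this position; the only step available, the one from compound 1 to compound 2, concerns chain length and shows that a larger substituent here costs affinity. The entering group is smaller by heavy-atom count than the nonyl it replaces, so a loss of the size seen for compound 2 is not expected, but the absence of any ring-bearing comparator leaves the direction open.

Compound 3 is therefore expected to land near compound 1, estimated at 60 nM (range 15 nM to 250 nM), a step of a 1.9-fold higher number from compound 1 to compound 3 (0.29 log units; within the scatter) that could fall within the scatter.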

Compound 3, inhibition constant: 640 nM
Estimate against measurement, compound 3: 11-fold (1.03 log units) below; measured number above the stated range.
By their numbers in this assay, from the lowest: compound 1; then compound 2; then compound 3.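

In this assay, placing the group with 2 five-membered non-aromatic rings of carbon only on the amide-type nitrogen in place of nonyl gives a 21-fold higher number from compound 1 to compound 3 (1.31 log units; beyond the scatter) and is classed as a large step, whereas lengthening the chain gives a 5.3-fold higher number from compound 1 to compound 2 (0.72 log units; beyond the scatter) and is classed as modest. Heavy-atom count alone therefore does not order these three compounds: the group in compound 3 is smaller than nonyl and the chain in compound 2 is larger, yet both changes raise the number, leaving nonyl with the lowest value of the set. No available data bear on why the ring-bearing group costs more than the longer chain.

The compounds shown leave open how the number changes with chains shorter than nonyl, such as hexyl, or with chains close to it, such as octyl or decyl, so the best chain length at this position is not fixed. They also leave open whether a single ring such as cyclohexyl, or a nonyl-length chain ending in an amine or a carboxylic acid, would keep the value of compound 1.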